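Dichlorophenyl sulfonyl replaces acetamidophenyl on a pyridine carbohydrazide

A few compounds are considered here, and "the series" means these few. Any claim that something is new, unique, unknown or untested is made for them only; others in the source may bear on it.

Measured in a functional assay on A498 cells (Homo sapiens) for antiproliferative activity; a lower number here means a stronger inhibitor of growth, a higher number a weaker inhibitor of growth:
Compound 1, `CC(=O)Nc1ccc(S(=O)(=O)NNC(=O)c2cccnc2Nc2ccc(Cl)cc2)cc1`, reaches only the assay limit of > 100000 nM.
Compound 2, `O=C(NNS(=O)(=O)c1ccc(F)cc1)c1cccnc1Nc1ccc(Cl)cc1Cl`, gives 36300 nM.

For compound 1 the numbers give no value, only the limit (the limit of > 100000 nM in this assay, at which 1 of the 2 values shown sits), so its standing in this assay is a floor of inactivity rather than a point. Going by the values given here, compound 2, which carries a fluorophenyl sulfonyl and a dichloroanilino group on the shared core, gives a real number, and the two values show only that compound 2 inhibits growth measurably where compound 1 does not.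

Compound 3, `O=C(NNS(=O)(=O)c1ccc(Cl)cc1Cl)c1cccnc1Nc1ccc(Cl)cc1`, is not yet measured. It differs from compound 1 in one place: 2,4-dichlorophenyl in place of 4-acetamidophenyl on a sulfonyl sulfur. Among the compounds with values here, no measured pair mirrors this change, so the expected step from compound 1 to compound 3, an at least 2.0-fold lower number from compound 1 to compound 3 (0.30 log units; that floor lies within the scatter), is an estimate towards stronger inhibition, supported only in that compound 2 with its halogenated aryl groups gives 36300 nM. Compound 3 is therefore expected at 50000 nM, in a range from 15000 nM to 150000 nM.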

Compound 3, concentration for total growth inhibition: 47900 nM
Beside the measured number, compound 3's estimate is 1.0-fold (0.02 log units) above it, within the range that was stated.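

In this assay, 2,4-dichlorophenyl in place of 4-acetamidophenyl on a sulfonyl sulfur gives an at least 2.0-fold lower number from compound 1 to compound 3 (0.31 log units; beyond the scatter), so a change at this position alone, with the rest of compound 1 held fixed, separates a measurable result from an assay limit. The earlier pair differed in more than one place and could not tie any difference to this position. The true size of the step stays unknown, and the printed size is only a floor, because compound 1 has a limit and not a point value: the limit of > 100000 nM in this assay, at which 1 of the 3 values shown sits.

The compounds shown do not separate the loss of the acetamido group from the arrival of the two chlorines. They also leave open how a phenyl ring carrying an amine or a carboxylic acid would behave on the sulfonyl sulfur.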